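A few compounds are considered here, and "the series" means these few. Any claim that something is new, unique, unknown or untested is made for them only; others in the source may bear on it.

Measured compounds in an assay on isolated protein for displacement of a labelled ligand from Orexin/Hypocretin receptor type 1 (Homo sapiens), with a stated time of 90 min; on this read-out higher numbers stand for weaker inhibition and lower numbers for stronger inhibition:
- compound 1 `COc1cc(F)c(CN2C(=O)N(c3cc(OC)nc(OC)c3)S(=O)(=O)c3ccccc32)c(F)c1`, 1 nM
- compound 2 `COc1ccc(N2C(=O)N(Cc3c(F)cc(F)cc3F)c3ccccc3S2(=O)=O)cc1OC`, 50.1 nM
- compound 3 `COc1cc(F)c(CN2C(=O)N(c3ccc(OC)c(OC)c3)S(=O)(=O)c3ccccc32)c(F)c1`, 2 nM

Compound 3 stands second highest of the three numbers. Its nearest neighbour is compound 1, with a 2.0-fold higher number from compound 1 to compound 3 (0.30 log units; within the scatter), a step that stays within the scatter. The furthest is compound 2: a 25-fold lower number from compound 2 to compound 3 (1.40 log units; beyond the scatter), a large step.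

Compound 4 `COc1ccc(N2C(=O)N(Cc3c(F)cc(F)cc3Cl)c3ccccc3S2(=O)=O)cc1OC` has not yet been measured in this assay. It differs from compound 3 in one place: 2-chloro-4,6-difluorophenyl in place of 2,6-difluoro-4-methoxyphenyl on a saturated chain carbon bound to an amide-type nitrogen in a ring. Among the compounds with values here, of the measured steps, only the one from compound 2 to compound 3 bears on this change, since it also concerns the group on the saturated chain carbon: there, methoxy in place of fluoro lowered the number by a 25-fold lower number from compound 2 to compound 3 (1.40 log units; beyond the scatter). Within the data shown here, compound 4 gives up the methoxy as compound 2 does, and in addition carries chlorine where compound 2 carries fluorine; no measured pair shows what that exchange does. The expectation is therefore a step back up toward compound 2, of roughly the size seen from compound 2 to compound 3, which as an estimate means a 20-fold higher number from compound 3 to compound 4 (1.30 log units; beyond the scatter). Compound 4 is expected at about 40 nM, with a range from 8 nM to 200 nM.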

Compound 4, inhibition constant: 25.1 nM
Compound 4: middle estimate off by 1.6-fold (0.20 log units), on the high side; low and high end bracket the measured number.
By their numbers in this assay, from the lowest: compounds 1 and 3 (each within the scatter of the next); then compounds 4 and 2 (each within the scatter of the next).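

Within the data shown here, the exchange of 2,6-difluoro-4-methoxyphenyl for 2-chloro-4,6-difluorophenyl on a saturated chain carbon bound to an amide-type nitrogen in a ring gives a 13-fold higher number from compound 3 to compound 4 (1.10 log units; beyond the scatter) in this assay and is a second large step away from the methoxy-bearing group, after the one seen with compound 2. Chloro in place of fluoro on an aromatic carbon gives a 2.0-fold lower number from compound 2 to compound 4 (0.30 log units; within the scatter) and that step stays within the scatter, so the two groups without methoxy cannot be told apart here, and among compound 2, compound 3 and compound 4 only compound 3 holds the low number. No evidence on hand bears on the cause of this difference.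

On these data alone, whether ethoxy, hydroxy or dimethylamino could stand in place of the methoxy and keep the low number stays open. Also open, as far as these compounds go, is whether 2-chloro-4,6-difluorophenyl on the saturated chain carbon gives a step of similar size when the 2,6-dimethoxypyridin-4-yl group of compound 1 sits on the other amide-type nitrogen.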